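A Cap on the Amine of Compound 2

The source may hold more compounds than are shown below. What is called first, only, known or untested is meant among the compounds shown, and "the series" means these compounds.

Of the compounds shown here, three sharing one core have been tested in an ADME assay on HepG2 cells (Homo sapiens) for cytotoxicity, read by fluorescence and resazurin assay, with a stated time of 24 h; on this read-out higher numbers stand for lower toxicity in this test and lower numbers for higher toxicity in this test. Compound 2 `Nc1ccc(-c2nnc(SC3=CS(=O)(=O)c4ccccc43)o2)cc1` gives 24000 nM. Compound 3 `O=S1(=O)C=C(Sc2nnc(-c3ccccn3)o2)c2ccccc21` gives 24000 nM, the same figure, and compound 1 `O=S1(=O)C=C(Sc2nnc(C3CCCCC3)o2)c2ccccc21` gives 15000 nM. Compound 2 therefore stands level with compound 3 and within the scatter of compound 1.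

The next compound, compound 4 `CC(=O)Nc1ccc(-c2nnc(SC3=CS(=O)(=O)c4ccccc43)o2)cc1`, differs from compound 2 by acetyl in place of hydrogen on a nitrogen on an aromatic ring, which turns amino to acetamido. Among the compounds with values here, no measured step makes this exact change. The closest evidence comes from swapping the group on an aromatic carbon of the core: a 1.6-fold higher number from compound 1 to compound 2 (0.20 log units; within the scatter), a 1.6-fold higher number from compound 1 to compound 3 (0.20 log units; within the scatter) and no change at the digits printed from compound 2 to compound 3 (within the scatter). All three stayed within the scatter, so no step beyond the scatter is expected in this assay, although three compounds are thin evidence. The estimated step is a 1.1-fold lower number from compound 2 to compound 4 (0.04 log units; within the scatter). Compound 4 is expected at 22000 nM, with an estimated range from 10000 nM to 48000 nM.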

Compound 4, half-maximal cytotoxic concentration: 31000 nM
The estimate for compound 4 lay 1.4-fold (0.15 log units) below the measured number, and the stated range covers the measured number.
By their numbers in this assay, from the lowest: compounds 1, 2, 3 and 4 (each within the scatter of the next, the first and the last beyond it).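

Acetyl in place of hydrogen is the first change shown on the nitrogen rather than on the aromatic carbon of the shared core, and in this assay it gives a 1.3-fold higher number from compound 2 to compound 4 (0.11 log units; within the scatter) for the whole molecule. The free amino group of compound 2 is therefore not required to keep this number within the scatter, since the acetamido group of compound 4 stays inside it as well. No measurement shown explains why this cap leaves the number within the scatter.

Still open, from the compounds shown here alone, is whether this holds for a longer chain on the same nitrogen, such as butanoyl, or for a methanesulfonyl group there. A single step also cannot show how a carboxylic acid in place of the amino group would read in this assay.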